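Series notes: acylguanidines tested for acid-sensing ion channel 3 inhibition

The source may hold more compounds than are shown below. What is called first, only, known or untested is meant among the compounds shown, and "the series" means these compounds.

Measured compounds:
compound 1 `NC(N)=NC(=O)c1nc(Cl)c(NCc2ccccc2Cl)nc1N` gives 90%
compound 2 `NC(N)=NC(=O)c1nc(Cl)c(N2CCCC2)nc1N` gives 84%
compound 3 `NC(N)=NC(=O)c1nc(Cl)c(N2CCc3ccccc32)nc1N` gives 89%

All three were run in an assay for inhibition of acid-sensing ion channel 3 (Homo sapiens), read by patch clamp, tested at 20 uM; on this read-out lower numbers stand for less inhibition and higher numbers for more inhibition at the one concentration tested (going by the name of the read-out). Compound 2 stands at the lowest of the three numbers, but compound 3 lies within the usual scatter of it, and so does compound 1, so the three values cannot be ranked. The shared core carries an amine-linked group on an aromatic carbon in every measured case.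

Compound 4 `NC(N)=NC(=O)c1nc(Cl)c(Oc2ccccc2)nc1N` has not yet been measured. It differs from compound 2 in one place: phenoxy in place of pyrrolidin-1-yl on an aromatic carbon. Among the compounds with values here, no measured pair in this set shows what such a change does, since every measured compound keeps a nitrogen-linked group at that carbon; the step must be guessed.

The estimated step of a number 10 percentage points lower from compound 2 to compound 4 (within the scatter) is expected to go downward, most likely by an amount not far beyond the scatter, with considerable uncertainty. Compound 4 is therefore expected to give about 74%, within a range from 50% to 92%.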

Compound 4, a percentage reported as inhibition, at one concentration (the size of the read-out at that concentration, not a potency): 90%
Compound 4: middle estimate off by 16 percentage points, on the low side; low and high end bracket the measured number.
By their numbers in this assay, from the lowest: compounds 2, 3, 1 and 4 (each within the scatter of the next).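

Phenoxy in place of pyrrolidin-1-yl on this aromatic carbon, next to the ring nitrogen, gives a number 6 percentage points higher from compound 2 to compound 4 (within the scatter) in this assay. Within the data shown here, compound 4 is the only compound in the set with an oxygen-linked group at this carbon, so the nitrogen link shared by compounds 1, 2 and 3 is not required for a reading of this size at the one concentration tested. Nothing available explains why the two groups give readings within the scatter of each other.

Still open, on these data alone, is how a carboxylic acid, a methoxy group or a bare hydrogen at this carbon would read, and whether phenoxy would read alike with an amine in place of the chloro group. Single-concentration readings also leave any potency differences among the four compounds unresolved.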